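Fluoro in place of hydrogen on compound 3

The source may hold more compounds than are shown below. What is called first, only, known or untested is meant among the compounds shown, and "the series" means these compounds.

In a functional assay on DU-145 cells (Homo sapiens) for cytotoxicity, read by trypan blue exclusion, with a stated time of 96 h (a higher number here means a weaker inhibitor, a lower number a stronger inhibitor), compound 1 `COc1cc(OC)c(/C=C/S(=O)(=O)Nc2ccc(F)c(N)c2)c(OC)c1` gives 10000 nM, compound 2 `COc1ccc(NS(=O)(=O)/C=C/c2ccc(OC)cc2OC)cc1` gives 15000 nM and compound 3 `COc1ccc(NS(=O)(=O)/C=C/c2c(OC)cc(OC)cc2OC)cc1` gives 200 nM, the lowest of the three numbers. Compound 4 `COc1cc(OC)c(/C=C/S(=O)(=O)Nc2ccc(OC)c(F)c2)c(OC)c1` is not yet measured. It differs from compound 3 by fluoro in place of hydrogen on an aromatic carbon, ortho to a methoxy group, turning 4-methoxyphenyl into 3-fluoro-4-methoxyphenyl.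

For the measured compounds named here, two measured steps bear on this. The first, a 50-fold lower number from compound 1 to compound 3 (1.70 log units; beyond the scatter), accompanies 4-methoxyphenyl in place of 3-amino-4-fluorophenyl on a sulfonamide nitrogen, a larger change than the one at issue. The second, a 75-fold lower number from compound 2 to compound 3 (1.88 log units; beyond the scatter), accompanies methoxy in place of hydrogen on an aromatic carbon, a different substitution. Neither step isolates fluoro in place of hydrogen, so neither size carries over, and no step beyond the scatter is expected in this assay. The estimated step is a 1.3-fold lower number from compound 3 to compound 4 (0.12 log units; within the scatter). Compound 4 is estimated at 150 nM, with an expected range of 30 nM to 800 nM.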

Compound 4, half-maximal inhibitory concentration: 200 nM
Beside the measured number, compound 4's estimate is 1.3-fold (0.12 log units) below it; the range from low to high includes it.
By their numbers in this assay, from the lowest: compounds 3 and 4 (each within the scatter of the next); then compounds 1 and 2 (each within the scatter of the next).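

In this assay, for the compounds shown here, fluoro in place of hydrogen on this aromatic carbon, ortho to a methoxy group, gives no change at the digits printed from compound 3 to compound 4 (within the scatter), the first reading at this position: here the hydrogen can give way to a fluoro with no shift beyond the scatter. The 3-fluoro-4-methoxyphenyl group also keeps the full advantage over 3-amino-4-fluorophenyl on the sulfonamide nitrogen, with a 50-fold lower number from compound 1 to compound 4 (1.70 log units; beyond the scatter), the same size as a 50-fold lower number from compound 1 to compound 3 (1.70 log units; beyond the scatter). No measurement on hand explains why this position responds so little to the fluoro.

Still open, from the compounds shown here alone, is whether the position stays as permissive for a chloro, a hydroxy or a nitrile in place of the fluoro. Also open, going by these compounds, is whether the fluoro reads the same on the core of compound 2.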